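Aryl swap on the enone chain: thiophene in place of hydroxyphenyl

This account rests on a few compounds, and the source may have more. Where it says the series, first, only, none or still open, it means among the compounds named here.

Compound 1 `O=C(/C=C/c1nccs1)c1cc(O)c(O)c([N+](=O)[O-])c1` and compound 2 `O=C(/C=C/c1cccc(O)c1)c1cc(O)c(O)c([N+](=O)[O-])c1` share one core and differ only in the aryl group on the double-bonded chain carbon. In an assay on isolated protein for inhibition of Amine oxidase [flavin-containing] B (Homo sapiens), read by fluorescence (on this read-out lower numbers stand for stronger inhibition and higher numbers for weaker inhibition), compound 1 gives 59200 nM and compound 2 gives 55800 nM; the step of a 1.1-fold lower number from compound 1 to compound 2 (0.03 log units; within the scatter) shows the two to lie within the scatter of each other, so no order between them can be read. Compound 3 `O=C(/C=C/c1cccs1)c1cc(O)c(O)c([N+](=O)[O-])c1` is not yet measured; it carries thiophen-2-yl in place of 3-hydroxyphenyl on a double-bonded chain carbon bound to a double-bonded chain carbon. Going by the values given here, the only step that bears on this change is the one from compound 1 to compound 2, where a five-membered heteroaryl against the hydroxyphenyl moved this assay by a 1.1-fold lower number from compound 1 to compound 2 (0.03 log units; within the scatter), that is, not beyond the scatter. A step of similar size, none beyond the scatter, is therefore expected for compound 3, as a 1.0-fold higher number from compound 2 to compound 3 (0.01 log units; within the scatter). Compound 3 is accordingly estimated at 57000 nM in this assay, within a range of 25000 nM to 130000 nM.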

Compound 3, half-maximal inhibitory concentration: 62900 nM
For compound 3 the middle estimate is 1.1-fold (0.04 log units) below the measured one; the measured number falls inside the stated range.
By their numbers in this assay, from the lowest: compounds 2, 1 and 3 (each within the scatter of the next).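

In this assay thiophen-2-yl on a double-bonded chain carbon bound to a double-bonded chain carbon gives a 1.1-fold higher number from compound 2 to compound 3 (0.05 log units; within the scatter) and a 1.1-fold higher number from compound 1 to compound 3 (0.03 log units; within the scatter) so all three aryl groups now stand level at this place. The exchange of 3-hydroxyphenyl for thiophen-2-yl removes the hydrogen-bond donor and replaces the six-membered aromatic ring with a five-membered one, yet the number stays inside the scatter. No measurement bears on why these groups read alike.

Open, as far as these compounds go, is whether a group of another kind at this place, such as an amine, a carboxylic acid or a longer chain, would move the number beyond the scatter. From the compounds shown here alone, the shared core is the same throughout, so what its own groups contribute also stays open.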